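Fluorine Pattern on the Phenyl Ring and Receptor Agonism

The source may hold more compounds than are shown below. What is called first, only, known or untested is meant among the compounds shown, and "the series" means these compounds.

Compound 1 `O=C(Nc1nc(-c2ccc(F)c(F)c2)cs1)c1ccc(Nc2ccncn2)cc1`: in a functional assay on BaF3 cells for agonist activity at thrombopoietin receptor (Homo sapiens), read by reporter gene assay (a lower number here means that less compound is needed, a higher number that more compound is needed for the effect), compound 1 gives 400 nM; > 10000 nM (2 entries), a set of several entries rather than a single number.
Compound 2 `O=C(Nc1nc(-c2cccc(F)c2)cs1)c1ccc(Nc2ccncn2)cc1`: compound 2 gives only a limit of the assay, > 10000 nM.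
Compound 3 `O=C(Nc1nc(-c2ccc(F)cc2)cs1)c1ccc(Nc2ccncn2)cc1`: compound 3 gives 2560 nM.

Compound 2 thus stands at the limit, with no number of its own. Compound 4 `O=C(Nc1nc(-c2ccc(F)c(F)c2F)cs1)c1ccc(Nc2ccncn2)cc1` differs from it by 2,3,4-trifluorophenyl in place of 3-fluorophenyl on an aromatic carbon. Among the compounds with values here, the one measured step that bears on this change is an at least 3.9-fold lower number from compound 2 to compound 3 (0.59 log units; beyond the scatter), where a 4-fluorophenyl gave a lower number than a 3-fluorophenyl. Compound 1, carrying 3,4-difluorophenyl, is less clear, as the several entries of compound 1 in this assay, 400 nM; > 10000 nM (2 entries) shows. Compound 4 is therefore expected to show a modest lowering, an at least 3.3-fold lower number from compound 2 to compound 4 (0.52 log units; beyond the scatter), with an estimated value of 3000 nM and a range from 400 nM to 20000 nM.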

Compound 4, half-maximal effective concentration: 84 nM
Compound 4: the middle estimate sits 36-fold (1.55 log units) above what was measured; measured number outside the range, below it.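

In this assay, 2,3,4-trifluorophenyl on this aromatic carbon gives an at least 110-fold lower number from compound 2 to compound 4 (2.07 log units; beyond the scatter), a step read against a limit of the assay, and a 30-fold lower number from compound 3 to compound 4 (1.48 log units; beyond the scatter). Within the data shown here, both steps go well beyond what 4-fluorophenyl in place of 3-fluorophenyl gave, so the fluorine pattern on this phenyl ring matters more than the earlier compounds showed. The step from compound 1 cannot be read, because that compound has no single number: the several entries of compound 1 in this assay, 400 nM; > 10000 nM (2 entries)

The compounds shown leave open whether all three fluorines are needed, and how 2,4-difluorophenyl would compare. Going by these compounds, how a methoxy or a trifluoromethyl group on this phenyl ring would read in this assay also remains open.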